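Sulfamoyl for Dimethylamino on a Weak Malate Dehydrogenase Inhibitor

A few compounds are considered here, and "the series" means these few. Any claim that something is new, unique, unknown or untested is made for them only; others in the source may bear on it.

Of the compounds shown here, three sharing one core have been measured in an assay on isolated protein with malate dehydrogenase, mitochondrial (Sus scrofa) as the target; a lower number here means a stronger inhibitor, a higher number a weaker inhibitor. Compound 1 `CN(C)c1ccc2c(O)c(C(=O)O)cnc2c1` gives 479000 nM in this assay, the highest number of the three. Compound 2 `O=C(O)c1cnc2cc(OCc3c(Cl)c(Cl)c(Cl)c(Cl)c3Cl)ccc2c1O` reaches 4790 nM in this assay, and compound 3 `O=C(O)c1cnc2cc(OCCOc3ccc(F)cc3)ccc2c1O` gives 18200 nM in this assay. Among the measured compounds shown here, both of these stand well apart from compound 1, each difference lying beyond the usual scatter of the measurement, so compound 1 is the weakest inhibitor among the compounds measured so far.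

Compound 4 `NS(=O)(=O)c1ccc2c(O)c(C(=O)O)cnc2c1` has not yet been measured in this assay. It differs from compound 1 in a single place: sulfamoyl in place of dimethylamino on an aromatic carbon. The carboxylic acid and hydroxyl on the shared core are untouched.

No measured pair separates a change of this kind, so nothing shown here tells how this assay answers to the swap. The two stronger compounds carry quite different, larger groups, and do not report on a small exchange of this sort. The author expects the step of a 1.6-fold lower number from compound 1 to compound 4 (0.20 log units; within the scatter) to be modest, falling inside or only slightly beyond the scatter, with no firm direction. Compound 4 is therefore estimated at 300000 nM in this assay, within a range from 70000 nM to 1000000 nM.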

Compound 4, half-maximal inhibitory concentration: 955000 nM
Compound 4: middle estimate off by 3.2-fold (0.50 log units), on the low side, within the range that was stated.
By their numbers in this assay, from the lowest: compound 2; then compound 3; then compounds 1 and 4 (each within the scatter of the next).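

In this assay, sulfamoyl in place of dimethylamino on this aromatic carbon gives a 2.0-fold higher number from compound 1 to compound 4 (0.30 log units; within the scatter), so this single exchange does not separate the two compounds in the measurement. Among the compounds shown here, this is the first pair that differs only at this position, and it shows that a group carrying a hydrogen-bond donor and two double bonds outside aromatic rings can take the place of dimethylamino, which has neither, without the number leaving the scatter. No measurement shown here bears on why the two groups read alike.

For the compounds shown here, with only this one exchange reported on its own, it remains open whether other small groups on this aromatic carbon, such as an amine, a carboxylic acid or a methoxy group, would also stay within the scatter of compound 1 or move the number beyond it. As far as these compounds go, it is also open whether a longer chain on the same carbon, built up one atom at a time from the dimethylamino or sulfamoyl compounds, would change the reading in this assay.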